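Trimming an Ethyl to a Methyl: Cytotoxicity Outlook

The compounds below may be only part of what the source reports. "The series", "measured", "known", "first", "only" and "open" are said of these compounds alone.

Compound 1 `CCn1nnc(-c2ccc(OCCC(C)CCN3CCN(c4ccncc4)C3=O)cc2)n1` was tested in an ADME assay on cells (Homo sapiens) for cytotoxicity; on this read-out higher numbers stand for lower toxicity in this test and lower numbers for higher toxicity in this test. In this assay compound 1 gives > 12500 nM, which is a limit of the assay and not a number. Compound 2 `O=C1N(CCC(CCOc2ccc(-c3ccc(Cl)cc3)cc2)Cc2ccccc2)CCN1c1ccncc1` also reaches only a limit in this assay, > 10000 nM. Compound 3 `CC(CCCN1CCN(c2ccncc2)C1=O)COc1ccc(-c2ccc(Cl)cc2)cc1` likewise gives > 25000 nM in this assay, again a limit. So compound 1 stands among three values of which every one is a limit rather than a measured number: the limit of > 10000 nM in this assay, at which 1 of the 3 values shown sits, the limit of > 12500 nM in this assay, at which 1 of the 3 values shown sits, and (the limit of > 25000 nM in this assay, at which 1 of the 3 values shown sits). Within the data shown here, no step between two measured compounds can be drawn from these limits.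

Compound 4 `CC(CCOc1ccc(-c2nnn(C)n2)cc1)CCN1CCN(c2ccncc2)C1=O` differs from compound 1 in one place: hydrogen in place of methyl on a saturated chain carbon bound to an aromatic nitrogen, which reads as ethyl to methyl on the shared core. With every shown value a limit and no measured step to lean on, the expected change in this assay from compound 1 to compound 4 is none beyond the usual scatter. The step that this estimate means is a step that the limit leaves unreadable from compound 1 to compound 4. Compound 4 is therefore expected to give about 15000 nM in this assay, with a range from 6000 nM to 40000 nM, and most probably once more only a limit.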

Compound 4, half-maximal cytotoxic concentration: > 25000 nM
Compound 4: no number, only a limit; the forecaster's own chance of this, stated with the estimate: 80%; at least 1.6-fold (0.22 log units) between middle value and limit.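

Compound 1 and compound 4 each reach only a limit in this assay, so no step can be read for the change from ethyl to methyl. The compounds shown leave open how far any of them lies past its limit, and whether going from 2-ethyl-2H-tetrazol-5-yl to 2-methyl-2H-tetrazol-5-yl alters this read-out at all.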